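A few compounds are considered here, and "the series" means these few. Any claim that something is new, unique, unknown or untested is made for them only; others in the source may bear on it.

Compound 1 `Cc1cc(C)cc(S(=O)(=O)c2c(C(=O)NC(C)C(=O)NCc3ccncc3)[nH]c3ccc(Cl)cc23)c1` gives 19500 nM in an ADME assay on MT4 cells (Homo sapiens) for cytotoxicity, read by MTT assay; on this read-out lower numbers stand for higher toxicity in this test and higher numbers for lower toxicity in this test.
Compound 2 `Cc1cc(C)cc(S(=O)(=O)c2c(C(=O)NC(C)c3ccco3)[nH]c3ccc(Cl)cc23)c1` gives only a limit in this assay, > 54700 nM, so its exact number is not known; it sits at the limit of > 54700 nM in this assay, at which 1 of the 2 values shown sits.

Compound 3 `Cc1cc(C)cc(S(=O)(=O)c2c(C(=O)NC(C)C(=O)NC(C)c3ccncc3)[nH]c3ccc(Cl)cc23)c1` has not yet been measured. It differs from compound 2 by (1-(pyridin-4-yl)ethyl)carbamoyl in place of furan-2-yl on a saturated chain carbon bound to an amide-type nitrogen and a saturated chain carbon. For the measured compounds named here, the one measured step that bears on this change is an at least 2.8-fold higher number from compound 1 to compound 2 (0.44 log units; beyond the scatter), which ran the opposite way through a closely related swap. Undoing that swap, a modest fall in the number is expected for compound 3, with an at least 2.7-fold lower number from compound 2 to compound 3 (0.43 log units; beyond the scatter). Compound 3 is therefore estimated at 20000 nM, in the range 8000 nM to 55000 nM.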

Compound 3, half-maximal cytotoxic concentration: 21900 nM
Beside the measured number, compound 3's estimate is 1.1-fold (0.04 log units) below it, within the range that was stated.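

The methyl on a saturated chain carbon bound to an amide-type nitrogen and an aromatic carbon gives a 1.1-fold higher number from compound 1 to compound 3 (0.05 log units; within the scatter) in this assay, so this added group makes no readable difference here. Replacing furan-2-yl with the larger (1-(pyridin-4-yl)ethyl)carbamoyl gives an at least 2.4-fold lower number from compound 2 to compound 3 (0.39 log units; beyond the scatter). The true size of that step is unknown, since compound 2 has only a limit of the assay: the limit of > 54700 nM in this assay, at which 1 of the 3 values shown sits.

Whether the pyridin-4-yl ring or the carbamoyl link accounts for the lower number stays open. So does how an amine or a carboxylic acid at this position would read.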